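This account rests on a few compounds, and the source may have more. Where it says the series, first, only, none or still open, it means among the compounds named here.

Compound 2 `COc1cc(/C=N/NC(=O)Nc2ccc(Oc3ccnc(-c4nncn4CCN(C)C)c3)c(F)c2)ccc1O` is one of two measured compounds here. In a functional assay on A549 cells (Homo sapiens) for cytotoxicity, read by MTT assay, with a stated time of 72 h (a lower number here means a stronger inhibitor, a higher number a weaker inhibitor), compound 2 reaches only the limit of the assay, > 100000 nM. Compound 1 `CN(C)CCn1cnnc1-c1cc(Oc2ccc(NC(=O)N/N=C/c3ccc(O)c(O)c3)cc2F)ccn1` likewise gives only a limit in this assay, > 100000 nM. Among the measured compounds shown here, the single measured step, a step that the two limits leave unreadable from compound 1 to compound 2, methyl in place of hydrogen on an oxygen on an aromatic ring, cannot be sized, since (the limit of > 100000 nM in this assay, at which 2 of the 2 values shown sit). Compound 3 `CN(C)CCn1cnnc1-c1cc(Oc2ccc(NC(=O)N/N=C/c3ccc(O)cc3O)cc2F)ccn1` has not yet been measured in this assay. It differs from compound 2 in 2,4-dihydroxyphenyl in place of 4-hydroxy-3-methoxyphenyl on a carbon with a double bond to nitrogen, in words 2,4-dihydroxyphenyl in place of 4-hydroxy-3-methoxyphenyl on a carbon with a double bond to nitrogen. For the measured compounds named here, the only measured step concerns the same aryl group and is unreadable, and both measured compounds sit at the limit, as the limit of > 100000 nM in this assay, at which 2 of the 2 values shown sit, records. Compound 3 is therefore expected to remain at that limit, with an expected step of a number no higher from compound 2 to compound 3 (the limit leaves the size open), none beyond the scatter. The estimate for compound 3 in this assay is 100000 nM, expected to lie between 30000 nM and 300000 nM.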

Compound 3, half-maximal inhibitory concentration: 12700 nM
Compound 3: the middle estimate sits 7.9-fold (0.90 log units) above what was measured; the whole stated range lies above it.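

In this assay, the aryl group on the carbon with a double bond to nitrogen can bring a compound off the limit, which the unreadable step between the first two compounds could not show: the change to 2,4-dihydroxyphenyl gives an at least 7.8-fold lower number from compound 2 to compound 3 (0.89 log units; beyond the scatter). The same group in place of 3,4-dihydroxyphenyl gives an at least 7.8-fold lower number from compound 1 to compound 3 (0.89 log units; beyond the scatter), so two aryl groups with the same two hydroxyl substituents, differently placed, read clearly apart. Both steps give only a minimum size, as each starts from a limit: the limit of > 100000 nM in this assay, at which 2 of the 3 values shown sit.

With a single value off the limit, the compounds shown do not tell whether both hydroxyl groups of 2,4-dihydroxyphenyl are needed for this step. Going by these compounds, how an amine in place of either hydroxyl group would read also stays open.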